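The source may report more compounds than this note shows. Statements on the series, on what has been measured and on what is new or still open speak of the compounds shown alone.

Three compounds of the series carry numbers in a functional assay on A549 cells (Homo sapiens) for cytotoxicity, read by MTT assay, with a stated time of 24 h; on this read-out higher numbers stand for weaker inhibition and lower numbers for stronger inhibition. Compound 1 `Cc1ncc([N+](=O)[O-])n1CCOc1ccccc1` gives 107 ug/mL. Compound 2 `Cc1cc(OCCn2c([N+](=O)[O-])cnc2C)ccc1Cl` gives 150 ug/mL. Compound 3 `Cc1ncc([N+](=O)[O-])n1CCn1ccnc1` gives 240 ug/mL, the highest of the three numbers; its gap to compound 2 lies within the scatter, its gap to compound 1 lies beyond it. No pair among these three differs in one place only, so no single-change step has yet been read in this assay.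

Compound 4 `Cc1nccn1CCn1c([N+](=O)[O-])cnc1C` is not yet measured. It differs from compound 3 by methyl in place of hydrogen on an aromatic carbon. Among the compounds with values here, nothing among the measured compounds shows what this change does in this assay, and the change is a small one. The expectation for the step from compound 3 to compound 4 is therefore no change at the digits printed from compound 3 to compound 4 (within the scatter), that is, no move beyond the scatter in either direction. On that basis compound 4 is expected to give 240 ug/mL in this assay, within a range from 130 ug/mL to 450 ug/mL.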

Compound 4, half-maximal inhibitory concentration: 195 ug/mL
For compound 4 the middle estimate is 1.2-fold (0.09 log units) above the measured one; the measured number falls inside the stated range.
By their numbers in this assay, from the lowest: compounds 1, 2, 4 and 3 (each within the scatter of the next, the first and the last beyond it).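

In this assay, methyl in place of hydrogen on an aromatic carbon, between two ring nitrogen atoms and next to the ring atom that bears a large group, gives a 1.2-fold lower number from compound 3 to compound 4 (0.09 log units; within the scatter), the first single-change step read in this series. The earlier compounds shown here could not show this, as none of them differs from another in one place only; at this position the added methyl leaves the number within the scatter. Nothing at hand gives a reason for this outcome.

On these data alone, whether a larger group at this position, such as ethyl, or a different one, such as an amine or a carboxylic acid, would move the number beyond the scatter remains open. This single step also cannot say whether methyl in place of hydrogen elsewhere on the shared core would behave the same way.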